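A few compounds are considered here, and "the series" means these few. Any claim that something is new, unique, unknown or untested is made for them only; others in the source may bear on it.

Compound 1 `COc1cccc(/C=C/C(=O)/C=C/c2ccc(OCc3cn(CCCOc4cc(=O)oc5ccccc45)nn3)c(OC)c2)c1`: 55%
Compound 2 `COc1cc(/C=C/C(=O)/C=C/c2ccccc2)ccc1OCc1cn(CCCOc2cc(=O)oc3ccccc23)nn1`: 45%

In a functional assay on HCT-116 cells (Homo sapiens) for inhibition, read by sulforhodamine B assay, with a stated time of 48 h, tested at 50 uM (on this read-out lower numbers stand for less inhibition of growth and higher numbers for more inhibition of growth at the one concentration tested), compound 2 gives 45% and compound 1 gives 55%. Within the data shown here, these two numbers lie within the usual scatter of each other, so this assay does not separate the pair, and compound 2 stands level with the only other measured compound.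

The next compound to consider is compound 3 `COc1cc(/C=C/C(=O)/C=C/c2cc(OC)c(OC)c(OC)c2)ccc1OCc1cn(CCCOc2cc(=O)oc3ccccc23)nn1`. It keeps the rest of compound 2 and changes one group: 3,4,5-trimethoxyphenyl in place of phenyl on a double-bonded chain carbon bound to a double-bonded chain carbon.

Among the measured compounds shown here, one measured step bears on this change, a number 10 percentage points lower from compound 1 to compound 2 (within the scatter). There, a hydrogen takes the place of a methoxy on an aromatic carbon, so it also concerns methoxy groups on an aromatic ring. That step stays within the scatter, which gives little reason to expect a large move here. For the measured compounds named here, compound 3 carries more methoxy groups than compound 1, however, and no measurement yet shows what that adds.

The expected change is small and is not expected to clearly exceed the scatter: a number 7 percentage points higher from compound 2 to compound 3 (within the scatter). For compound 3 the estimated value is 52%, with an expected range of 36% to 70%.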

Compound 3, percent growth inhibition at one concentration: 76%
For compound 3 the middle estimate is 24 percentage points below the measured one; the whole stated range lies below it.
By their numbers in this assay, from the lowest: compounds 2 and 1 (each within the scatter of the next); then compound 3.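

In this assay, among these compounds, the aromatic ring on this double-bonded chain carbon proves able to move the read-out: 3,4,5-trimethoxyphenyl in place of phenyl gives a number 31 percentage points higher from compound 2 to compound 3 (beyond the scatter), the first step to pass the scatter. The same group also stands clear of 3-methoxyphenyl at this place, with a number 21 percentage points higher from compound 1 to compound 3 (beyond the scatter), so compound 3 separates from both simpler compounds, a separation that the earlier pair could not show. No measurement shown here accounts for this gain.

The compounds shown leave open whether all three methoxy groups are needed, or whether a ring with two of them would read as high as compound 3. Also open, on these data alone, is how a phenyl carrying hydroxyl groups, fluorine atoms or an amine in place of the methoxy groups would read at this position, and whether the gain seen at this one concentration in this one cell line would hold in a full dose-response measurement or in other cell lines.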